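The source may report more compounds than this note shows. Statements on the series, on what has been measured and on what is new or still open speak of the compounds shown alone.

Compound 1, `COc1ccc2[nH]cc(Cc3nn4c(Cc5ccc(OC)c(OC)c5)nnc4s3)c2c1`: in a functional assay on the whole organism (strain Wistar Albino) for inhibition, with Rattus norvegicus as the target, read by paw edema, with a stated time of 3 h, at a dose of 20 mg/kg (a lower number here means less inhibition, a higher number more inhibition at the dose given (going by the name of the read-out)), compound 1 gives 19.1%.
Compound 2, `COc1ccc2[nH]cc(Cc3nn4c(-c5ccoc5C)nnc4s3)c2c1`: in this assay compound 2 gives 26.1%.
Compound 3, `COc1ccc2[nH]c(C)c(Cc3nn4c(-c5ccoc5C)nnc4s3)c2c1`: in this assay compound 3 gives 29.4%.

All three compounds share the same core and were each tested at one dose. Among the three numbers, compound 2 stands second highest, yet neither neighbour is truly apart from it: the change from compound 2 to compound 3, methyl in place of hydrogen on an aromatic carbon, gave a number 3.3 percentage points higher from compound 2 to compound 3 (within the scatter), and the value of compound 1 also falls within the scatter of that of compound 2. On these numbers the three compounds cannot be told apart.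

Compound 4, `Cc1occc1-c1nnc2sc(Cc3c[nH]c4ccccc34)nn12`, differs from compound 2 by hydrogen in place of methoxy on an aromatic carbon. For the measured compounds named here, the only measured single step, from compound 2 to compound 3 with a number 3.3 percentage points higher from compound 2 to compound 3 (within the scatter), concerns a different change on a different part of the molecule and stayed within the scatter. Going by the values given here, no measured step shows a methoxy leaving this ring, so nothing in the data points up or down. The expectation for this assay is therefore no step beyond the scatter. Compound 4 is estimated at 24%, with a range from 12% to 36%. That estimate corresponds to an expected step of a number 2.1 percentage points lower from compound 2 to compound 4 (within the scatter).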

Compound 4, a percentage reported as inhibition, in the whole organism at one dose (the size of the read-out at that dose, not a potency): 26.5%
Beside the measured number, compound 4's estimate is 2.5 percentage points below it, within the range that was stated.
By their numbers in this assay, from the lowest: compounds 1, 2, 4 and 3 (each within the scatter of the next, the first and the last beyond it).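

For the compounds shown here, with hydrogen in place of methoxy on an aromatic carbon of the six-membered ring, the compounds gave a number 0.4 percentage points higher from compound 2 to compound 4 (within the scatter) and so offer the first look at this position, as compounds 1, 2 and 3 all carry the methoxy group. In this assay, going by these compounds alone, at the single dose given, taking away the two heavy atoms and the hydrogen-bond acceptor of the methoxy group therefore left no step that can be told apart from the ordinary spread of repeated measurements, which means the read-out gives no sign that this group is needed for the effect seen. Nothing measured here explains this result or shows what the methoxy group does in the animal.

Whether a hydroxyl group, a chlorine atom, an amine or a longer chain such as ethoxy at this place would move the number beyond the scatter remains open, with only methoxy and hydrogen shown there. Also open, from the compounds shown here alone, is whether the same change would leave the number just as little altered on compound 1 or compound 3, whose cores differ elsewhere from that of compound 2.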